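Notes on compound 4, the ethoxy analogue of compound 2

The compounds below may be only part of what the source reports. "The series", "measured", "known", "first", "only" and "open" are said of these compounds alone.

In an ADME assay on HeLa cells (Homo sapiens) for cytotoxicity (on this read-out higher numbers stand for lower toxicity in this test and lower numbers for higher toxicity in this test), compound 1 `Cc1ccc(/C=N/N(C(=O)c2ccccc2)C(=O)c2ccncc2)cc1` gives 100 ug/mL. Compound 2 `COc1cc(/C=N/N(C(=O)c2ccccc2)C(=O)c2ccncc2)ccc1O` gives 100 ug/mL, and the step of no change at the digits printed from compound 1 to compound 2 (within the scatter) stays within the scatter, so compound 2 stands level with compound 1 at the digits shown. Compound 3 `CSc1ccc(/C=N/N(C(=O)c2ccccc2)C(=O)c2ccncc2)cc1` sits at a limit of this assay, > 100 ug/mL. Because of the limit of > 100 ug/mL in this assay, at which 1 of the 3 values shown sits, the steps of a number no lower from compound 1 to compound 3 (the limit leaves the size open) and a number no lower from compound 2 to compound 3 (the limit leaves the size open) are of unreadable size. Compound 4 `CCOc1cc(/C=N/N(C(=O)c2ccccc2)C(=O)c2ccncc2)ccc1O` differs from compound 2 by methyl in place of hydrogen on a saturated chain carbon bound to an oxygen on an aromatic ring. Going by the values given here, the only readable step, from compound 1 to compound 2, moved nothing beyond the scatter, and no measured step speaks against compound 4. Compound 4 is therefore expected at 100 ug/mL, between 50 ug/mL and 200 ug/mL. The step of no change at the digits printed from compound 2 to compound 4 (within the scatter) is expected to fall within the scatter, with a fair chance that only a limit is reported.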

Compound 4, minimum cytotoxic concentration: > 100 ug/mL
Compound 4 was reported as a limit; the forecaster's own chance of this, stated with the estimate: 40%; the middle value lies on the limit itself.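

Methoxy to ethoxy is the only change at this position among the compounds shown, and it gives a number no lower from compound 2 to compound 4 (the limit leaves the size open). In this assay compound 4 is a limit, > 100 ug/mL, not a number. So one added methyl on this saturated chain carbon brings no fall on this read-out, though the size of the step cannot be read, and the upper end of the series stays unresolved: the limit of > 100 ug/mL in this assay, at which 2 of the 4 values shown sit.

On these data alone, whether a longer chain such as propoxy, or an amine in place of the ethoxy, would give a readable number remains open.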